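Replacing nitro with amino on the aryl group of compound 1

The source may report more compounds than this note shows. Statements on the series, on what has been measured and on what is new or still open speak of the compounds shown alone.

In a functional assay on the whole organism with Mus musculus as the target (on this read-out lower numbers stand for an effect already at smaller amounts and higher numbers for an effect only at larger amounts of compound), compound 1 `COc1cc2c(cc1OC)C(c1cccc([N+](=O)[O-])c1)=NNC(=O)C2` is recorded only as a limit, > 120 umol/kg. Compound 2 `COc1cc2c(cc1OC)C(c1ccc([N+](=O)[O-])cc1)=NNC(=O)C2` also gives only a limit, > 120 umol/kg. Among the measured compounds shown here, the series so far therefore offers only (the limit of > 120 umol/kg in this assay, at which 2 of the 2 values shown sit), and no measured number anchors either compound.

Compound 3 `COc1cc2c(cc1OC)C(c1cccc(N)c1)=NNC(=O)C2` keeps the core of compound 1 and carries amino in place of nitro on an aromatic carbon, meta to a large group: amino in place of nitro on an aromatic carbon.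

For the measured compounds named here, no measured step covers this change, so its size is a matter of judgement. A moderate move toward lower numbers in this assay is expected, although a result that again reaches only the limit remains a real possibility. The estimated step of an at least 2.0-fold lower number from compound 1 to compound 3 (0.30 log units; that floor lies within the scatter) is a rough one, and its starting point is a limit and not a number. For compound 3 the estimated value is 60 umol/kg. The expected range for that estimate runs from 20 umol/kg to 150 umol/kg.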

Compound 3, dose for half-maximal effect: 18.3 umol/kg
Compound 3: the middle estimate sits 3.3-fold (0.52 log units) above what was measured; measured number outside the range, below it.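

Amino in place of nitro on an aromatic carbon, meta to a large group, gives the series its first measured number in this assay, and the change reads as an at least 6.5-fold lower number from compound 1 to compound 3 (0.81 log units; beyond the scatter). The two nitro compounds showed only that the read-out stayed at the limit, whereas compound 3 shows that this position on the aryl group can carry a group with an effect at a measurable dose, so the nitro group is not needed there for activity in this whole-animal read-out. The step is a floor and its true size cannot be read, as its starting point is a limit and not a number: the limit of > 120 umol/kg in this assay, at which 2 of the 3 values shown sit.

Going by these compounds, with amino as the only replacement for nitro at this position, it stays open whether a hydroxyl, a methylamino or an acetylamino group on the same carbon would also give a number, and how much of the step belongs to amino itself. Also open, on these data alone, is whether amino in place of the nitro group of compound 2 would bring that compound off the limit as well.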